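Bromine position on the phenoxy group: compound 3 to compound 4

A few compounds are considered here, and "the series" means these few. Any claim that something is new, unique, unknown or untested is made for them only; others in the source may bear on it.

In a functional assay on HL-60 cells (Homo sapiens) for antiproliferative activity, read by MTT assay, with a stated time of 72 h (on this read-out higher numbers stand for weaker inhibition and lower numbers for stronger inhibition), compound 3 (`NC1=NC2(CCSCC2)N(OCCCOc2ccc(Br)cc2)C(N)=N1`) gives 350 nM and lies within the scatter of compound 1 (`CC(C)(C)c1ccc(OCCCON2C(N)=NC(N)=NC23CCSCC3)cc1`), which gives 280 nM on the shared core. Compound 2 (`COc1ccc(OCCCON2C(N)=NC(N)=NC23CCOCC3)cc1`) gives 1670 nM and stands apart from compound 3 by a gap beyond the scatter, toward the higher number. Compound 2 differs from compound 3 in more than one place, so that gap cannot be assigned to any single change.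

Compound 4 (`NC1=NC2(CCSCC2)N(OCCCOc2ccccc2Br)C(N)=N1`) has the same atoms as compound 3, joined differently: 2-bromophenyl in place of 4-bromophenyl on an oxygen on a saturated carbon. Going by the values given here, one measured step bears on this, and only indirectly: a 1.3-fold higher number from compound 1 to compound 3 (0.10 log units; within the scatter) (bromo in place of tert-butyl on an aromatic carbon). Among the compounds with values here, that step exchanges one group for another, whereas no measured pair shows the bromine moved. Resting on that step (a 1.3-fold higher number from compound 1 to compound 3 (0.10 log units; within the scatter)) as the sole guide, no change beyond the scatter is expected in this assay and any lean toward a higher number is weakly held. The estimated step is a 1.2-fold higher number from compound 3 to compound 4 (0.09 log units; within the scatter) and is expected to stay small. For compound 4 the estimate is 430 nM with an expected range of 150 nM to 1200 nM in this series.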

Compound 4, half-maximal inhibitory concentration: 180 nM
Estimate against measurement, compound 4: 2.4-fold (0.38 log units) above; low and high end bracket the measured number.
By their numbers in this assay, from the lowest: compounds 4, 1 and 3 (each within the scatter of the next); then compound 2.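

In this assay, moving the bromine, with 2-bromophenyl in place of 4-bromophenyl on an oxygen on a saturated carbon, gives a 1.9-fold lower number from compound 3 to compound 4 (0.29 log units; within the scatter) and so stays within the scatter, which means this pair shows no measurable dependence on where the bromine sits among these two placings. The earlier step, a 1.3-fold higher number from compound 1 to compound 3 (0.10 log units; within the scatter), exchanged one group for another and said nothing about placement, whereas this pair holds the atoms fixed and changes only how they are joined, so the two bromophenoxy isomers can be treated as equivalent in this assay for now. No measured property accompanies this pair, and nothing shown speaks to what lies behind the step.

On these data alone, whether the same holds for a group other than bromo on the 2-position of the phenyl ring, such as an amine or a carboxylic acid, stays open, as does the effect of a longer chain in place of the one that carries the phenoxy group. Compound 2 differs from compound 3 and compound 4 in more than one place, so neither its methoxy group nor its core can be read separately against them.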